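Piperidine in Place of a Carboxymethylamino Group

A few compounds are considered here, and "the series" means these few. Any claim that something is new, unique, unknown or untested is made for them only; others in the source may bear on it.

Three measured compounds share one core and differ only in the group on a saturated chain carbon bound to an aromatic carbon. Compound 1 is `COCc1ncnc2c1ncn2[C@@H]1O[C@H](CO)[C@@H](O)[C@H]1O`, compound 2 is `OC[C@H]1O[C@@H](n2cnc3c(COc4ccccc4)ncnc32)[C@H](O)[C@@H]1O` and compound 3 is `O=C(O)CNCc1ncnc2c1ncn2[C@@H]1O[C@H](CO)[C@@H](O)[C@H]1O`. In a functional assay on Huh-7 cells (Homo sapiens) for cytotoxicity, read by MTT assay, with a stated time of 3 days (on this read-out lower numbers stand for higher toxicity in this test and higher numbers for lower toxicity in this test), compound 3 gives only a limit of the assay, > 100000 nM. Compound 1 likewise gives only a limit, > 100000 nM. Compound 2 also gives only a limit, > 100000 nM. The steps among them, a step that the two limits leave unreadable from compound 1 to compound 2, a step that the two limits leave unreadable from compound 1 to compound 3 and a step that the two limits leave unreadable from compound 2 to compound 3, therefore cannot be sized, since all three values sit at the limit of > 100000 nM in this assay, at which 3 of the 3 values shown sit.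

Compound 4 is `OC[C@H]1O[C@@H](n2cnc3c(CN4CCCCC4)ncnc32)[C@H](O)[C@@H]1O`. It differs from compound 3 in one place: piperidin-1-yl in place of (carboxymethyl)amino on a saturated chain carbon bound to an aromatic carbon.

The three measured steps bear on this change only by showing that a methoxy, a phenoxy and a (carboxymethyl)amino group at this position all left toxicity outside the range of this assay, and none of them offers a size to carry over. For compound 4 no step beyond the scatter in either direction is expected. The estimate means a step that the limit leaves unreadable from compound 3 to compound 4. Compound 4 is expected to give about 150000 nM, between 40000 nM and 500000 nM, and most likely to be reported again only as a limit.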

Compound 4, half-maximal cytotoxic concentration: 87000 nM
Beside the measured number, compound 4's estimate is 1.7-fold (0.24 log units) above it; measured number inside the range.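

In this assay, among these compounds, compound 4 is the first compound with a group at this place, on a saturated chain carbon bound to an aromatic carbon, to give a number rather than a limit: 87000 nM. Set against the three earlier compounds, this gives steps with a floor but no upper end: an at least 1.1-fold lower number from compound 3 to compound 4 (0.06 log units; that floor lies within the scatter), an at least 1.1-fold lower number from compound 2 to compound 4 (0.06 log units; that floor lies within the scatter) and an at least 1.1-fold lower number from compound 1 to compound 4 (0.06 log units; that floor lies within the scatter). Piperidin-1-yl thus puts the read-out inside the range that the assay can report, but each floor lies within the scatter, so no real difference from the earlier groups is established, and the size of these steps stays unreadable because the other values are limits: the limit of > 100000 nM in this assay, at which 3 of the 4 values shown sit.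

On these data alone, it remains open whether the six-membered ring itself matters or whether an amine nitrogen bound directly to this carbon with no hydrogen-bond donor is enough, which an open-chain group such as diethylamino would test. Smaller or altered rings, such as pyrrolidin-1-yl or morpholin-4-yl, leave open how far a number at this place depends on the exact ring.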